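Trimming the chain between two amide groups

The source may hold more compounds than are shown below. What is called first, only, known or untested is meant among the compounds shown, and "the series" means these compounds.

Three compounds share one large core and carry, at the end of a flexible chain, an iodoacetamide-type group. In an assay on isolated protein for inhibition of hexokinase-3 (Rattus norvegicus), with a stated time of 6 h, tested at 10 mM (on this read-out lower numbers stand for less inhibition and higher numbers for more inhibition at the one concentration tested (going by the name of the read-out)), compound 1 `O=C(CI)NCCCC(=O)NCCCCCCNc1ncnc2c1ncn2[C@@H]1O[C@H](COP(=O)(O)OP(=O)(O)OP(=O)(O)O)[C@@H](O)[C@H]1O` gives 0% and compound 3 `O=C(CI)NCCCCCC(=O)NCCCCCCNc1ncnc2c1ncn2[C@@H]1O[C@H](COP(=O)(O)OP(=O)(O)OP(=O)(O)O)[C@@H](O)[C@H]1O` gives 0%, level with compound 1 at the digits printed; these are together the lowest of the three numbers. Compound 2 `O=C(CI)NCCCCCCCNc1ncnc2c1ncn2[C@@H]1O[C@H](COP(=O)(O)OP(=O)(O)OP(=O)(O)O)[C@@H](O)[C@H]1O`, which lacks the inner amide segment, gives 20%, a step of a number 20 percentage points higher from compound 1 to compound 2 (beyond the scatter).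

Compound 4 `O=C(CI)NCCC(=O)NCCCCCCNc1ncnc2c1ncn2[C@@H]1O[C@H](COP(=O)(O)OP(=O)(O)OP(=O)(O)O)[C@@H](O)[C@H]1O` is a shorter relative of compound 3: ((iodomethyl)carbonyl)amino in place of 3-(((iodomethyl)carbonyl)amino)propyl on a saturated chain carbon, two bonds along the chain from a carbonyl carbon. Among the measured compounds shown here, two measured steps bear on this. Lengthening the same stretch, from compound 1 to compound 3, gave no change at the digits printed from compound 1 to compound 3 (within the scatter), so chain length at this position has so far moved nothing. Removing the inner amide entirely gave the only rise seen, a number 20 percentage points higher from compound 1 to compound 2 (beyond the scatter), but compound 4 keeps that amide. A step within the scatter is therefore expected, a number 5 percentage points higher from compound 3 to compound 4 (within the scatter), and compound 4 is estimated at 5%, between 0% and 20%.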

Compound 4, a percentage reported as inhibition, at one concentration (the size of the read-out at that concentration, not a potency): 0%
Estimate against measurement, compound 4: 5 percentage points above, within the range that was stated.
By their numbers in this assay, from the lowest: compounds 1, 3 and 4 (each within the scatter of the next); then compound 2.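

Shortening the stretch between the two amide groups changes the read-out no more than lengthening it did, with no change at the digits printed from compound 1 to compound 4 (within the scatter) and no change at the digits printed from compound 3 to compound 4 (within the scatter) in this assay, so three chain lengths that keep the inner amide now read alike. The rise seen for the chain without that amide also holds against this shorter relative, with a number 20 percentage points lower from compound 2 to compound 4 (beyond the scatter), so it no longer rests on compound 1 and compound 3 alone. No supporting measurement is available to explain why these chains read alike or why compound 2 stands apart.

From the compounds shown here alone, it remains open whether a longer chain without the inner amide would raise the number further. Also open, going by these compounds, is what would happen with a (chloromethyl)carbonyl amino group, an amine or a carboxylic acid at the chain end in place of ((iodomethyl)carbonyl)amino.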